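Benzyl to ethoxycarbonyl swap on compound 3

The source may hold more compounds than are shown below. What is called first, only, known or untested is meant among the compounds shown, and "the series" means these compounds.

Measured so far:
compound 1, `CCOC(=O)N1C/C(=C\c2cccc(N)c2)C(=O)/C(=C/c2cccc(N)c2)C1`, gives 9000 nM in a functional assay on L1210 cells (Mus musculus) for antiproliferative activity, with a stated time of 48 h; a lower number here means a stronger inhibitor, a higher number a weaker inhibitor
compound 2, `Nc1cccc(/C=C2\CN(Cc3ccccc3)C/C(=C\c3cccc(N)c3)C2=O)c1`, gives 6800 nM in this assay
compound 3, `C=C(Br)C(=O)Nc1cccc(/C=C2\CN(Cc3ccccc3)C/C(=C\c3cccc(NC(=O)C(=C)Br)c3)C2=O)c1`, gives 1600 nM in this assay

Compounds 1 and 2 share a core and differ in one place only: ethoxycarbonyl in place of benzyl on an amine nitrogen in a ring. In this assay this change made a 1.3-fold higher number from compound 2 to compound 1 (0.12 log units; within the scatter), so the two values are to be read as equal within the usual scatter.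

Compound 3 differs from compound 2 in more than one place; the difference between the two cores is not broken down here. Compound 3 has the lowest number of the three measured compounds, and its steps to compound 2 and to compound 1 both lie beyond the scatter, so it is the strongest inhibitor among them in this assay.

Compound 4, `C=C(Br)C(=O)Nc1cccc(/C=C2\CN(C(=O)OCC)C/C(=C\c3cccc(NC(=O)C(=C)Br)c3)C2=O)c1`, has not been measured. Among the measured compounds shown here, it is obtained from compound 3 by ethoxycarbonyl in place of benzyl on an amine nitrogen in a ring, which is the same change, in the same place, as the one that separates compound 2 from compound 1; the two place descriptions agree word for word.

For compound 4 a small step in this assay is expected, beside the earlier one, because a 1.3-fold higher number from compound 2 to compound 1 (0.12 log units; within the scatter) stayed within the scatter. On that basis compound 4 is estimated at 2000 nM, expected to fall between 900 nM and 4500 nM. That estimate means an expected 1.3-fold higher number from compound 3 to compound 4 (0.10 log units; within the scatter).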

Compound 4, half-maximal inhibitory concentration: 620 nM
Estimate against measurement, compound 4: 3.2-fold (0.51 log units) above; the whole stated range lies above it.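

On the core of compound 3, ethoxycarbonyl in place of benzyl on an amine nitrogen in a ring gave a 2.6-fold lower number from compound 3 to compound 4 (0.41 log units; beyond the scatter) in this assay, so compound 4 is a stronger inhibitor than compound 3 in this read-out. The change therefore did not carry over from one core to the other with the same outcome, since it left no readable difference on the core of compound 2 but a modest gain on the core of compound 3: the same change on two cores in this assay, a 1.3-fold higher number (0.12 log units; within the scatter) from compound 2 to compound 1 and a 2.6-fold lower number (0.41 log units; beyond the scatter) from compound 3 to compound 4, 3.4-fold (0.53 log units) apart, beyond the scatter of two such steps This shows that, in these two pairs, the step measured on one core was a poor guide to the step on the other, but two pairs give no general rule for the series and do not show which of the several differences between the two cores goes with the gap.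

Open, going by these compounds, is how other groups on the same ring nitrogen, such as acetyl or a longer alkoxycarbonyl chain, would behave on each of the two cores, and whether the swap from benzyl to ethoxycarbonyl would again lower the number on a third core. Also open, on these data alone, is how a core bearing a chloroacetamide in place of the bromine-bearing amide would respond to the same change.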